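This account rests on a few compounds, and the source may have more. Where it says the series, first, only, none or still open, it means among the compounds named here.

The study concerns a small group of nucleoside analogues sharing a bicyclic cyclic-phosphorus core tested in a functional assay on Raji cells (Homo sapiens) for antiproliferative activity; a lower number here means a stronger inhibitor, a higher number a weaker inhibitor. Going by the values given here, compound 1, `O=c1[nH]c(=O)n([C@H]2C[C@@H]3O[PH](O)(O)OC[C@H]3O2)cc1F`, is the one member for which a number is recorded: in this assay compound 1 gives 19 ug/mL, and it therefore stands alone as the only compound with a measured value. The other two values are limits of the assay. Compound 2, `COP1(=O)OC[C@H]2O[C@@H](n3cc(Br)c(=O)[nH]c3=O)C[C@@H]2O1`, reaches only a limit of the assay, > 100 ug/mL. Compound 3, `O=c1[nH]c(=O)n([C@H]2C[C@@H]3OP(=O)(OCc4ccccc4)OC[C@H]3O2)cc1I`, likewise reaches only a limit of the assay, > 100 ug/mL. Among the compounds with values here, these two compounds differ from compound 1 in more than one place, so no single change can be read from them, and no step between measured compounds is available; the one fact is the limit of > 100 ug/mL in this assay, at which 2 of the 3 values shown sit.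

Compound 4, `O=c1[nH]c(=O)n([C@H]2C[C@@H]3O[PH](O)(O)OC[C@H]3O2)cc1Cl`, has not yet been measured. Its difference from compound 1 is chloro in place of fluoro on an aromatic carbon. Within the data shown here, with no measured step to lean on, the expectation for compound 4 is a move toward weaker inhibition, estimated as a 3.2-fold higher number from compound 1 to compound 4 (0.50 log units; beyond the scatter), a step judged likely to exceed the scatter. On that basis compound 4 is expected to give about 60 ug/mL in this assay, within an estimated range from 15 ug/mL to 150 ug/mL.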

Compound 4, concentration for 50% inhibition: > 1000 ug/mL
Compound 4 was reported as a limit; the forecaster's own chance of this, stated with the estimate: 35%; middle value at least 16-fold (1.22 log units) from the limit.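

Going by these compounds alone, the step gives the first single change that can be read in this assay: chloro in place of fluoro on an aromatic carbon gives an at least 52-fold higher number from compound 1 to compound 4 (1.72 log units; beyond the scatter). Compound 4 gives > 1000 ug/mL, which is a limit of the assay and not a number. Compound 2 and compound 3 differ from compound 1 in more than one place, so only this pair shows that the value of compound 1 is lost when this one group is exchanged, with one heavy atom replacing another and the counts of hydrogen-bond donors and acceptors and the net charge unchanged, and the result sits at a limit of its own: the limit of > 1000 ug/mL in this assay, at which 1 of the 4 values shown sits.

The compounds shown leave open whether any group other than fluoro on this carbon of the core of compound 1, such as a methyl group, an amine or plain hydrogen, would keep a measurable value. They also leave open how bromo or iodo would behave on the core of compound 1, and how far beyond its limit compound 4 actually lies.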